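The source may hold more compounds than are shown below. What is called first, only, known or untested is meant among the compounds shown, and "the series" means these compounds.

Measured so far:
Compound 1, `O=C(O)Cc1sc(C(c2ccc(F)cc2)c2ccc(F)cc2)nc1-c1ccc(Cl)cc1`, gives 180 nM in an in vitro functional assay on HEK285-7 cells for antagonist activity at prostaglandin D2 receptor 2 (Homo sapiens), read by BRET and beta-arrestin recruitment; on this read-out higher numbers stand for weaker inhibition and lower numbers for stronger inhibition.
Compound 2, `Nc1cc(-c2nc(C(c3ccc(F)cc3)c3ccc(F)cc3)sc2CC(=O)O)cc(F)n1`, gives 1400 nM in this assay.

Among the measured compounds shown here, compound 2 stands highest of the two numbers, with compound 1 as its only neighbour. Compound 3, `O=C(O)Cc1sc(C(c2ccc(F)cc2)c2ccc(F)cc2)nc1-c1ccnc(N2CCC2)c1`, carries 2-(azetidin-1-yl)pyridin-4-yl in place of 2-amino-6-fluoropyridin-4-yl on an aromatic carbon. For the measured compounds named here, the single measured step that bears on it is a 7.8-fold higher number from compound 1 to compound 2 (0.89 log units; beyond the scatter), an exchange of the whole aryl group at the same position; no measured step exchanges one substituted pyridine for another. A modest move back toward compound 1 is therefore expected, and for compound 3 the expected step is a 2.3-fold lower number from compound 2 to compound 3 (0.37 log units; beyond the scatter) in this assay. Compound 3 is estimated at 600 nM, within 150 nM to 2500 nM.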

Compound 3, half-maximal inhibitory concentration: > 100000 nM
Compound 3 was reported as a limit; the forecaster's own chance of this, stated with the estimate: 5%; middle value at least 160-fold (2.22 log units) away from the limit.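

Compound 3 is reported only as a limit of the assay, not as a number: the limit of > 100000 nM in this assay, at which 1 of the 3 values shown sits. On the aromatic carbon next to the ring nitrogen, exchanging one substituted pyridine for another gives an at least 71-fold higher number from compound 2 to compound 3 (1.85 log units; beyond the scatter) in this assay, so this position responds to more than the change of 4-chlorophenyl to a pyridine, which gave a 7.8-fold higher number from compound 1 to compound 2 (0.89 log units; beyond the scatter). Measured from the 4-chlorophenyl group, the change amounts to an at least 550-fold higher number from compound 1 to compound 3 (2.74 log units; beyond the scatter).

As far as these compounds go, whether the azetidine ring, the absent amine or the absent fluorine governs this step stays open. From the compounds shown here alone, how an open-chain dimethylamino group would read in place of the azetidine also stays open.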